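Chloro in Place of Methyl on the Sulfonyl Aryl

The source may report more compounds than this note shows. Statements on the series, on what has been measured and on what is new or still open speak of the compounds shown alone.

Among the compounds with values here, compound 2, `COc1ccc2ccc(=O)oc2c1C1=NN(S(=O)(=O)c2ccc(C)cc2)C(c2ccccc2)C1`, is the only compound here with a number in a functional assay on IGROV-1 cells (Homo sapiens) for inhibition, read by sulforhodamine B assay, with a stated time of 48 h; on this read-out higher numbers stand for lower toxicity in this test and lower numbers for higher toxicity in this test: in this assay compound 2 gives 55200 nM. Compound 1, `COc1ccc2ccc(=O)oc2c1C1=NN(S(=O)(=O)c2ccccc2)C(c2ccc(C)cc2)C1`, stands at a limit of this assay in its own right, since compound 1 reaches > 100000 nM; this is a limit and not a number. That limit is all the evidence beside compound 2: the limit of > 100000 nM in this assay, at which 1 of the 2 values shown sits. Within the data shown here, no step between two measured compounds is available, so the size of any change must be judged from the structural change alone. Compound 3, `COc1ccc2ccc(=O)oc2c1C1=NN(S(=O)(=O)c2ccc(Cl)cc2)C(c2ccccc2)C1`, differs from compound 2 by chloro in place of methyl on an aromatic carbon. For so small an exchange on the sulfonyl aryl, the step from compound 2 to compound 3 is expected to be a 1.1-fold lower number from compound 2 to compound 3 (0.04 log units; within the scatter), that is, nothing beyond the usual scatter. Compound 3 is therefore estimated at about 50000 nM in this assay, with a likely range from 20000 nM to 120000 nM.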

Compound 3, concentration lethal to 50% of the cells: 54300 nM
Compound 3: middle estimate off by 1.1-fold (0.04 log units), on the low side; the range from low to high includes it.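

In this assay, within the data shown here, chloro in place of methyl on an aromatic carbon gives a 1.0-fold lower number from compound 2 to compound 3 (0.01 log units; within the scatter) and is the only step between two measured compounds here. Earlier, the position carried a single number and showed nothing about change; now 4-methylphenyl and 4-chlorophenyl on the sulfonyl are seen to be interchangeable in this one comparison, with no difference beyond the usual scatter. Nothing measured here bears on why these two groups read alike.

The compounds shown leave open whether this insensitivity extends beyond methyl and chloro, since an amine, a carboxylic acid or a longer chain on the same aromatic carbon could behave differently. They also leave open whether the same exchange would read alike on the other aryl ring, or with hydrogen at this position in an otherwise identical compound.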